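Adding a Methoxy Group to a Terpenoid Cytotoxin Series

This account rests on a few compounds, and the source may have more. Where it says the series, first, only, none or still open, it means among the compounds named here.

Compound 1 `CC(C)=CCC/C(C)=C/CC/C(C)=C/CC[C@@H]1[C@@]2(C)CC/C(=N\OCc3cn(-c4ccccc4)nn3)C(C)(C)[C@@H]2CC[C@@]1(C)O`: 7760 nM
Compound 2 `COc1cccc(-n2cc(CO/N=C3\CC[C@]4(C)[C@@H](CC/C=C(\C)CC/C=C(\C)CCC=C(C)C)[C@](C)(O)CC[C@H]4C3(C)C)nn2)c1`: 22900 nM
Compound 3 `CC(C)=CCC/C(C)=C/CC/C(C)=C/CC[C@@H]1[C@@]2(C)C/C(=C\c3ccc(OCc4cn(-c5ccccc5)nn4)cc3)C(=O)C(C)(C)[C@@H]2CC[C@@]1(C)O`: 36300 nM

All three were tested in a functional assay on HeLa cells (Homo sapiens) for cytotoxicity, read by MTT assay, with a stated time of 48 h; on this read-out higher numbers stand for weaker inhibition and lower numbers for stronger inhibition. Compound 2 differs from compound 1 by methoxy in place of hydrogen on an aromatic carbon, and that change gave a 3.0-fold higher number from compound 1 to compound 2 (0.47 log units; beyond the scatter). Going by the values given here, compound 3 carries a different core; how the two cores differ is not broken down here, and no step between them is counted, so their two values show only that compound 3 sits at a higher number than compound 1, while compound 2 and compound 3 lie within the usual scatter of each other.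

Compound 4 `COc1cccc(-n2cc(COc3ccc(/C=C4\C[C@]5(C)[C@@H](CC/C=C(\C)CC/C=C(\C)CCC=C(C)C)[C@](C)(O)CC[C@H]5C(C)(C)C4=O)cc3)nn2)c1` has not yet been measured. It differs from compound 3 by methoxy in place of hydrogen on an aromatic carbon, the same change at the same kind of place that separates compound 2 from compound 1. Because that earlier change gave a 3.0-fold higher number from compound 1 to compound 2 (0.47 log units; beyond the scatter), a shift of similar size is expected, so the step from compound 3 to compound 4 is estimated at a 2.5-fold higher number from compound 3 to compound 4 (0.39 log units; beyond the scatter). Compound 4 is therefore expected to give about 90000 nM, most likely between 35000 nM and 220000 nM, in this assay.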

Compound 4, half-maximal inhibitory concentration: 16200 nM
The estimate for compound 4 lay 5.6-fold (0.74 log units) above the measured number; measured number outside the range, below it.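

In this assay, replacing phenyl with 3-methoxyphenyl made the compound on the second core more potent, with a 2.2-fold lower number from compound 3 to compound 4 (0.35 log units; beyond the scatter), so the change moved the number in the opposite direction from the one seen on the first core. The effect of this methoxy therefore did not carry from one core to the other: the same change on two cores in this assay, a 3.0-fold higher number (0.47 log units; beyond the scatter) from compound 1 to compound 2 and a 2.2-fold lower number (0.35 log units; beyond the scatter) from compound 3 to compound 4, 6.6-fold (0.82 log units) apart, beyond the scatter of two such steps. This shows that, for these two pairs, a step measured on one core was a poor guide to the step on the other, but it does not show which feature of the cores lies behind the reversal, and two pairs cannot set a general rule for the series.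

The compounds shown leave open whether another group in the same place, such as a hydroxyl, an amine or a carboxylic acid, would also behave differently on the two cores. They also leave open whether the reversal would appear in cell lines other than HeLa.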